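The source may report more compounds than this note shows. Statements on the series, on what has been measured and on what is new or still open speak of the compounds shown alone.

Measured compounds in the series:

compound 1, `O=[N+]([O-])c1cn2c(n1)OC[C@@H](NCc1ccc(OC(F)(F)F)cc1F)C2`: 0.242 h
compound 2, `O=[N+]([O-])c1cn2c(n1)OC[C@@H](NCc1ccc(OC(F)(F)F)c(O)c1)C2`: 0.373 h
compound 3, `O=[N+]([O-])c1cn2c(n1)OC[C@@H](NCc1ccc(OC(F)(F)F)cc1O)C2`: 0.238 h

All three numbers come from an in vitro ADME assay on the whole organism (microsomes, liver, Mus musculus) for metabolic stability, read by LC-MS, with a stated time of 24 h, at a dose of 5 mg/kg by the intravenous route; on this read-out lower numbers stand for a shorter-lived compound and higher numbers for a longer-lived compound. In this assay compound 3 gives 0.238 h and compound 1 gives 0.242 h; the two are joined by a single change, (fluoro in place of hydroxy on an aromatic carbon), and the step of a 1.0-fold higher number from compound 3 to compound 1 (0.01 log units; within the scatter) is within the scatter, so the two numbers cannot be told apart. Compound 2 gives 0.373 h in this assay; its gaps to compound 1 and to compound 3 are both within the scatter as well, so no ordering among the three is supported. The difference between the cores of compound 2 and compound 3 is not broken down here.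

Compound 4, `O=[N+]([O-])c1cn2c(n1)OC[C@@H](NCc1ccc(OC(F)(F)F)c(F)c1)C2`, is not yet measured. It arises from compound 2 by fluoro in place of hydroxy on an aromatic carbon. For the measured compounds named here, this is the same kind of change as the one from compound 3 to compound 1, not the same change: in the earlier pair the changed carbon is ortho to a large group and meta to a trifluoromethoxy group, whereas in compound 4 it is ortho to a trifluoromethoxy group and meta to a large group.

Going by the values given here, with only one measured instance of this kind of change to go on, the step from compound 2 to compound 4 is expected to be a 1.1-fold lower number from compound 2 to compound 4 (0.03 log units; within the scatter), resting on the step of a 1.0-fold higher number from compound 3 to compound 1 (0.01 log units; within the scatter), which was within the scatter. Compound 4 is therefore estimated at 0.35 h in this assay, with a range of 0.18 h to 0.7 h that allows for the different surroundings of the changed carbon.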

Compound 4, half-life: 0.393 h
For compound 4 the middle estimate is 1.1-fold (0.05 log units) below the measured one; low and high end bracket the measured number.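

In this assay, fluoro in place of hydroxy gives a 1.1-fold higher number from compound 2 to compound 4 (0.02 log units; within the scatter), with the changed carbon ortho to a trifluoromethoxy group and meta to a large group. Set beside the earlier pair, where the changed carbon has different surroundings, the change reads the same on both cores: the same change on two cores in this assay, a 1.0-fold higher number (0.01 log units; within the scatter) from compound 3 to compound 1 and a 1.1-fold higher number (0.02 log units; within the scatter) from compound 2 to compound 4, 1.0-fold (0.02 log units) apart, within the scatter of two such steps This shows only that the swap carries over between these two pairs without a step that can be told from the scatter; since neither step lies beyond the scatter, it gives no measurable effect of the change to transfer, and two pairs in one read-out establish no rule for the wider series.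

Still open, going by these compounds, is whether a group other than hydroxy or fluoro on the same aromatic ring, such as a methoxy group, a nitrile or an amine, would give a step beyond the scatter in this assay. Also open, on these data alone, is whether replacing the trifluoromethoxy group itself, for instance with a longer alkoxy chain, would move the half-life by more than the scatter, and whether the hydroxy-to-fluoro swap would then still read the same.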